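The source may report more compounds than this note shows. Statements on the series, on what has been measured and on what is new or still open speak of the compounds shown alone.

Of the compounds shown here, three sharing one core have been measured in an assay on THP-1 cells for displacement of a labelled ligand from C-C chemokine receptor type 1 (Homo sapiens); a lower number here means a stronger inhibitor, a higher number a weaker inhibitor. Compound 1 `CC(C)[C@@H](NC(=O)c1cccc(F)c1)C(=O)N1CCC(c2ccc(Cl)cc2)CC1` gives 24 nM. Compound 2 `Cc1ccccc1C(=O)N[C@@H](C(=O)N1CCC(c2ccc(Cl)cc2)CC1)C(C)C` gives 32 nM, and compound 3 `CC(C)CC(=O)N[C@@H](C(=O)N1CCC(c2ccc(Cl)cc2)CC1)C(C)C` gives 32 nM. For the measured compounds named here, compound 3 thus stands level with compound 2, together the highest of the three numbers, and compound 1 sits within the scatter of both, so no compound can be called stronger or weaker than another.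

Compound 4 `CC(C)[C@@H](NC(=O)NCc1ccccc1)C(=O)N1CCC(c2ccc(Cl)cc2)CC1` differs from compound 3 in one place: benzylamino in place of isobutyl on a carbonyl carbon. Seen one bond further out, isobutylcarbonyl becomes benzylcarbamoyl, so a hydrogen-bond donor enters at the carbonyl carbon.

The measured steps at this same carbonyl carbon are a 1.3-fold higher number from compound 1 to compound 2 (0.12 log units; within the scatter), a 1.3-fold higher number from compound 1 to compound 3 (0.12 log units; within the scatter) and no change at the digits printed from compound 2 to compound 3 (within the scatter). Each swap there, whether between two aromatic rings or between a ring and a branched chain, left the number where it was. None of these steps put a nitrogen-linked group on that carbon, so the present change reaches beyond what has been tested, and the range must be set wider. On that basis the step expected in this assay is no change at the digits printed from compound 3 to compound 4 (within the scatter), none beyond the scatter. Compound 4 is estimated at 32 nM, with a range from 10 nM to 110 nM.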

Compound 4, half-maximal inhibitory concentration: 180 nM
Compound 4: the middle estimate sits 5.6-fold (0.75 log units) below what was measured; measured number outside the range, above it.
By their numbers in this assay, from the lowest: compounds 1, 2 and 3 (each within the scatter of the next); then compound 4.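

For the compounds shown here, at this carbonyl carbon, the earlier swaps left the number in this assay within the scatter, but benzylamino is the first group to move it beyond the scatter: the change gives a 5.6-fold higher number from compound 3 to compound 4 (0.75 log units; beyond the scatter), a 5.6-fold higher number from compound 2 to compound 4 (0.75 log units; beyond the scatter) and a 7.5-fold higher number from compound 1 to compound 4 (0.88 log units; beyond the scatter). The position is therefore not indifferent to what it carries, and this change makes compound 4 a weaker inhibitor than each of the other three compounds. A six-membered aromatic ring alone does not go with the higher number, as compound 1 and compound 2 each carry one on this carbon and stand within the scatter of compound 3, and nothing measured here explains the rise seen with compound 4.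

In compound 4 the nitrogen link, with its hydrogen-bond donor, and the benzyl part arrive together, so the compounds shown cannot say which of them goes with the higher number. A 2-phenylethyl group on the same carbonyl carbon would keep the ring and drop the nitrogen, while isobutylamino would keep the nitrogen and drop the ring, and phenylamino would keep both without the benzyl carbon.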